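A Methyl Cap on the Chain of Compound 2

The source may hold more compounds than are shown below. What is called first, only, known or untested is meant among the compounds shown, and "the series" means these compounds.

Compound 1 `COCCCN1C(/C=C/c2ccc(O)cc2)=CC(=O)CC1c1ccc(O)cc1`, compound 2 `COc1cc(/C=C/C(=O)/C=C(/C=C/c2ccc(O)c(OC)c2)NCCCO)ccc1O` and compound 3 `COCCCNC(=C\C(=O)/C=C/c1ccc(O)cc1)/C=C/c1ccc(O)cc1` were tested in a functional assay on Caco-2 cells (Homo sapiens) for cytotoxicity, read by MTT assay, with a stated time of 48 h; a higher number here means a weaker inhibitor, a lower number a stronger inhibitor. For compound 1 the result in this assay is a limit of the assay, > 100000 nM, and not a number. That limit sits at the limit of > 100000 nM in this assay, at which 1 of the 3 values shown sits. Compound 2 gives 75700 nM in this assay, the highest of the two numbers shown, while compound 3 gives 24000 nM, and the gap between these two lies beyond the usual scatter of such measurements.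

Compound 4 `COCCCNC(=C\C(=O)/C=C/c1ccc(O)c(OC)c1)/C=C/c1ccc(O)c(OC)c1` has not yet been measured. It differs from compound 2 in one place: methyl in place of hydrogen on an oxygen on a saturated carbon. For the measured compounds named here, no pair of measured compounds differs by exactly this change, so there is no measured step to lean on. Compound 3 already carries a methyl on the oxygen of its chain, as compound 4 does, but it differs from compound 2 in two places, so its value shows only where one related compound lands. My expectation is a moderate step toward a lower number, a 1.9-fold lower number from compound 2 to compound 4 (0.28 log units; within the scatter), with the outcome uncertain because the measured values of compound 2, 75700 nM, and compound 3, 24000 nM, do not isolate this change. Compound 4 is expected to give 40000 nM in this assay, within a range from 15000 nM to 100000 nM.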

Compound 4, half-maximal inhibitory concentration: 49100 nM
Compound 4: the middle estimate sits 1.2-fold (0.09 log units) below what was measured; the range from low to high includes it.
By their numbers in this assay, from the lowest: compound 3; then compounds 4 and 2 (each within the scatter of the next). At a limit, above all of these: compound 1.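

In this assay, for the compounds shown here, the change from hydroxy to methoxy on this saturated carbon now has a measured size for the first time: a 1.5-fold lower number from compound 2 to compound 4 (0.19 log units; within the scatter). Before compound 4, no pair of measured compounds differed by this change alone, so the earlier values could show only where related compounds landed. The result shows that replacing this hydrogen with a methyl, which adds a single carbon to the chain, gives compound 4 a value that cannot be told apart from that of compound 2 in repeated measurements, and nothing measured here gives a reason for this outcome.

On these data alone, it remains open whether something larger or different at this place, such as a benzyl group on the oxygen, or an amine or a carboxylic acid in place of the hydroxy, would produce a step beyond the scatter. Also open, as far as these compounds go, is how the hydroxy forms of compound 1 and compound 3 would read, so it cannot yet be said whether this small step would hold on their cores as well.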